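The compounds below may be only part of what the source reports. "The series", "measured", "known", "first", "only" and "open" are said of these compounds alone.

Three close relatives of one shared core have been tested in a functional assay on CHO cells for agonist activity at Alpha-1A adrenergic receptor (Homo sapiens), read by FLIPR and calcium flux; on this read-out lower numbers stand for an effect already at smaller amounts and higher numbers for an effect only at larger amounts of compound. Compound 1 `COCc1ccccc1C1CCc2nc[nH]c2C1` gives 76 nM; 48 nM (2 entries), compound 2 `c1ccc(C2CCc3nc[nH]c3C2)cc1` gives 234 nM; 123 nM; 315 nM (3 entries), and compound 3 `Clc1ccccc1C1CCc2nc[nH]c2C1` gives 276 nM. Among the measured compounds shown here, for compound 3 this is the only number that exists in this assay; two further entries for it did not yield a single number. Its value lies above the two entries of compound 1 and alongside the three entries of compound 2.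

Compound 4 `COc1ccccc1C1CCc2nc[nH]c2C1` has not yet been measured. It differs from compound 3 in one place: methoxy in place of chloro on an aromatic carbon. For the measured compounds named here, no step between measured compounds carries this exact exchange, so the expected size of the step can only be read from the spread of the three measured compounds. Compound 1, with its values of 76 nM; 48 nM (2 entries), marks the low end of that spread, and compound 2, with 234 nM; 123 nM; 315 nM (3 entries), the high end together with compound 3. The expected step is a 2.1-fold lower number from compound 3 to compound 4 (0.33 log units; beyond the scatter), a modest lowering that may stay within the usual scatter. Compound 4 is therefore estimated at 130 nM, with a likely range from 45 nM to 380 nM.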

Compound 4, half-maximal effective concentration in the Alpha-1A adrenergic receptor assay: 144 nM
The estimate for compound 4 lay 1.1-fold (0.04 log units) below the measured number; the measured number falls inside the stated range.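

In the Alpha-1A adrenergic receptor assay, putting methoxy in place of chloro on this aromatic carbon gives a 1.9-fold lower number from compound 3 to compound 4 (0.28 log units; within the scatter), so a group with 1 hydrogen-bond acceptor can replace one with 0 hydrogen-bond acceptors without a shift that stands clear of repeat-to-repeat variation. In a physicochemical assay for lipophilicity, at pH 7.4 (a higher number here means a more lipophilic compound, a lower number a more polar compound), compound 3 gives 3.1 and compound 4 gives 2.8. In the physicochemical assay, the same exchange gives a number 0.30 log units lower from compound 3 to compound 4 (within the scatter), so on this read-out too the two compounds cannot be told apart. Back in the Alpha-1A adrenergic receptor assay, compound 4 at 144 nM sits among the repeated entries of compound 2, which carries neither group at this place, so the present numbers do not separate methoxy from the bare ring either: the several entries of compound 2 in the Alpha-1A adrenergic receptor assay, 234 nM; 123 nM; 315 nM (3 entries)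

It remains open whether the lower entries of compound 1, which carries a methoxymethyl group at this place, reflect a real gain over compound 4 and its shorter group: the several entries of compound 1 in the Alpha-1A adrenergic receptor assay, 76 nM; 48 nM (2 entries) The compounds shown also leave open how this place would respond to a group of a different kind, such as an amine or a carboxylic acid.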